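This account rests on a few compounds, and the source may have more. Where it says the series, first, only, none or still open, it means among the compounds named here.

Measured so far in a functional assay on HepG2 cells (Homo sapiens) for inhibition, read by MTT assay, with a stated time of 24 h; a higher number here means a weaker inhibitor, a lower number a stronger inhibitor:
Compound 1 `COc1ccccc1-n1cc(CN2C(=O)C[C@@H]3CC[C@@]2(C)C3(C)C)nn1` gives 110 nM.
Compound 2 `COc1ccc(-n2cc(CN3C(=O)C[C@@H]4CC[C@@]3(C)C4(C)C)nn2)cc1` gives 100 nM.
Compound 3 `Cc1ccc(-n2cc(CN3C(=O)C[C@@H]4CC[C@@]3(C)C4(C)C)nn2)cc1` gives 480 nM.

Compound 3 has the highest number of the three, and both gaps lie beyond the scatter: a 4.4-fold higher number from compound 1 to compound 3 (0.64 log units; beyond the scatter) and a 4.8-fold higher number from compound 2 to compound 3 (0.68 log units; beyond the scatter). Compound 4 `CC1(C)[C@H]2CC[C@]1(C)N(Cc1cn(-c3ccc(F)cc3)nn1)C(=O)C2` differs from compound 3 by fluoro in place of methyl on an aromatic carbon. Going by the values given here, no measured step swaps a methyl for a fluoro. The nearest guide is a 4.8-fold higher number from compound 2 to compound 3 (0.68 log units; beyond the scatter), a swap at the same aromatic carbon, which shows that the group there shifts the number by a modest amount. Whether fluoro behaves more like methyl or more like methoxy cannot be told from these three compounds, so only a wide range can be expected. Compound 4 is expected at 350 nM, between 120 nM and 1000 nM, an expected step of a 1.4-fold lower number from compound 3 to compound 4 (0.14 log units; within the scatter).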

Compound 4, half-maximal inhibitory concentration: 90 nM
The estimate for compound 4 lay 3.9-fold (0.59 log units) above the measured number, and the stated range ends above it.
By their numbers in this assay, from the lowest: compounds 4, 2 and 1 (each within the scatter of the next); then compound 3.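

At this aromatic carbon, fluoro in place of methyl brings a clear fall in the number (a 5.3-fold lower number from compound 3 to compound 4 (0.73 log units; beyond the scatter)), so methyl, not fluoro, is the group set apart from the rest. Fluoro and methoxy at this carbon cannot be told apart (a 1.1-fold lower number from compound 2 to compound 4 (0.05 log units; within the scatter)), and 4-fluorophenyl also reads level with the 2-methoxyphenyl group (a 1.2-fold lower number from compound 1 to compound 4 (0.09 log units; within the scatter)). Nothing at hand explains why methyl stands apart from these groups.

Open, going by these compounds, is whether chloro, an amine or a carboxylic acid at this carbon would read like fluoro or like methyl.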